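The source may report more compounds than this note shows. Statements on the series, on what has been measured and on what is new or still open speak of the compounds shown alone.

Working notes on the series, read in a functional assay on SK-OV-3 cells (Homo sapiens) for inhibition, read by CCK-8 assay, with a stated time of 70 h; on this read-out lower numbers stand for stronger inhibition and higher numbers for weaker inhibition. Compound 1 (`c1ccc(COc2ccc(OCCOCCNC3CCCCC3)cc2)cc1`) gives 7370 nM, and compound 2 (`c1ccc(COc2ccc(OCCOCCNc3cc[nH]c3)cc2)cc1`) gives 11300 nM. Compound 2 thus stands within the scatter of compound 1, and the two cannot be ranked. Compound 3 (`c1ccc(COc2ccc(OCCOCCNC3CCC3)cc2)cc1`) has cyclobutyl in place of 1H-pyrrol-3-yl on an amine nitrogen. Going by the values given here, the only measured step that bears on this change is a 1.5-fold higher number from compound 1 to compound 2 (0.19 log units; within the scatter), made on the same amine nitrogen and also involving 1H-pyrrol-3-yl. Among the compounds with values here, it lies within the scatter, and no measured compound yet carries cyclobutyl. No step beyond the scatter is therefore expected in this assay, and no direction can be claimed with confidence. The expected step is a 1.3-fold lower number from compound 2 to compound 3 (0.10 log units; within the scatter). For compound 3 the estimated value is 9000 nM, with an expected range of 3500 nM to 20000 nM.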

Compound 3, half-maximal inhibitory concentration: 25000 nM
Compound 3: the middle estimate sits 2.8-fold (0.44 log units) below what was measured; the measured number lies above the stated range.
By their numbers in this assay, from the lowest: compounds 1 and 2 (each within the scatter of the next); then compound 3.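

At this amine nitrogen the choice of group now registers in this assay: cyclobutyl in place of 1H-pyrrol-3-yl gives a 2.2-fold higher number from compound 2 to compound 3 (0.34 log units; beyond the scatter), and cyclobutyl in place of cyclohexyl gives a 3.4-fold higher number from compound 1 to compound 3 (0.53 log units; beyond the scatter). Going by these compounds alone, both steps are modest, but cyclohexyl and 1H-pyrrol-3-yl could not be ranked against each other, so cyclobutyl is the first group to stand apart, leaving compound 3 the weakest of the three. No measurement at hand explains this difference.

Open, as far as these compounds go, is whether a cyclopentyl group on the same nitrogen would fall with cyclohexyl or with cyclobutyl, and whether an open-chain isopropyl group would follow the rings. Also open, from the compounds shown here alone, is whether the step from cyclohexyl to cyclobutyl would hold on a longer chain than the shared one.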